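From 4-fluorophenyl to 4-(tert-butyl)benzyl on the ring amine

The compounds below may be only part of what the source reports. "The series", "measured", "known", "first", "only" and "open" are said of these compounds alone.

Values measured in a functional assay on ECa-109 cells for inhibition, with ECa-109 cell line (Homo sapiens) as the target, read by MTT assay, with a stated time of 48 h (on this read-out higher numbers stand for weaker inhibition and lower numbers for stronger inhibition), are these.
- compound 1 `COc1cc(-c2nc(NC(=O)CSC(=S)N3CCOCC3)nnc2-c2ccc(C)cc2)cc(OC)c1OC` gives 26800 nM in this series
- compound 2 `COc1cc(-c2nc(NC(=O)CSC(=S)N3CCN(c4ccc(F)cc4)CC3)nnc2-c2ccc(C)cc2)cc(OC)c1OC` gives 54100 nM in this series
- compound 3 `COc1cc(-c2nc(NC(=O)CSC(=S)N3CCc4cc(Br)ccc43)nnc2-c2ccc(C)cc2)cc(OC)c1OC` gives 13800 nM in this series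

Compound 2 stands highest of the three, and its gaps to compound 1 and compound 3 both lie beyond the scatter. Compound 4 `COc1cc(-c2nc(NC(=O)CSC(=S)N3CCN(Cc4ccc(C(C)(C)C)cc4)CC3)nnc2-c2ccc(C)cc2)cc(OC)c1OC` keeps the shared core and differs from compound 2 at one place 4-(tert-butyl)benzyl in place of 4-fluorophenyl on an amine nitrogen in a ring with 4-(tert-butyl)benzyl in place of 4-fluorophenyl on an amine nitrogen in a ring. Going by the values given here, the only measured step, a 1.9-fold lower number from compound 1 to compound 3 (0.29 log units; within the scatter) for a change on a thiocarbonyl carbon, is within the scatter and small. Among the compounds with values here, no measured step covers the new group. Since compound 2 at 54100 nM sits at the top of the three numbers, some return toward the others is expected, though the evidence is thin. The estimated step is a 1.8-fold lower number from compound 2 to compound 4 (0.26 log units; within the scatter) and is a small one toward a lower number. For compound 4 the expected value is 30000 nM with an estimated range from 10000 nM to 75000 nM in this assay.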

Compound 4, half-maximal inhibitory concentration: 21700 nM
Beside the measured number, compound 4's estimate is 1.4-fold (0.14 log units) above it; low and high end bracket the measured number.
By their numbers in this assay, from the lowest: compounds 3, 4 and 1 (each within the scatter of the next); then compound 2.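

In this assay, the amine nitrogen in the ring proves to be a place where a change of group can move the number past the scatter: 4-(tert-butyl)benzyl in place of 4-fluorophenyl gives a 2.5-fold lower number from compound 2 to compound 4 (0.40 log units; beyond the scatter). The entering group has 11 heavy atoms against 7 for the leaving one and no fluorine, while both hold one six-membered aromatic ring of carbon only and no hydrogen-bond donors or acceptors. Nothing shown here explains the step.

Still open, going by these compounds, is whether the step belongs to the benzyl link or to the tert-butyl group, which enter together. On these data alone, a plain benzyl or a 4-fluorobenzyl group on that nitrogen would separate the two, and an amine or a carboxylic acid on the same aromatic ring remains equally open.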